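The source may hold more compounds than are shown below. What is called first, only, known or untested is meant among the compounds shown, and "the series" means these compounds.

Of the compounds shown here, three share a core and have been tested in an assay on Sf9 cells for inhibition of protein deacetylase HDAC6 (Homo sapiens), read by fluorescence, with a stated time of 40 min, tested at 100 nM; on this read-out higher numbers stand for more inhibition at the one concentration tested (going by the name of the read-out) and lower numbers for less inhibition. Compound 1 `COc1ccc(-c2nc(CNc3ccc(C(=O)NO)cc3)n(-c3ccccc3)n2)cc1` gives 77.6%. Compound 2 `CCc1ccc(-n2nc(-c3ccccc3)nc2CNc2ccc(C(=O)NO)cc2)cc1` gives 38.3%. Compound 3 `O=C(NO)c1ccc(NCc2nc(-c3ccccc3)nn2-c2cccc(Cl)c2)cc1` gives 62.3%, the second highest of the three numbers: below compound 1 and above compound 2, both gaps beyond the scatter.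

Compound 4 `CC(C)c1ccc(-n2nc(-c3ccccc3)nc2CNc2ccc(C(=O)NO)cc2)cc1` is not yet measured. It differs from compound 3 in one place: 4-isopropylphenyl in place of 3-chlorophenyl on an aromatic nitrogen

Among the compounds with values here, one measured step bears on this change. In this assay the number rose a number 24 percentage points higher from compound 2 to compound 3 (beyond the scatter), when a 4-alkylphenyl gave way to 3-chlorophenyl. Compound 4 reverses that direction, putting a 4-alkylphenyl back on the aromatic nitrogen, so a drop of similar size is expected, a number 22.3 percentage points lower from compound 3 to compound 4 (beyond the scatter).

Compound 4 is therefore estimated at 40%, within a range of 25% to 58%.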

Compound 4, a percentage reported as inhibition, at one concentration (the size of the read-out at that concentration, not a potency): 52.6%
Compound 4: the middle estimate sits 12.6 percentage points below what was measured; measured number inside the range.
By their numbers in this assay, from the lowest: compound 2; then compounds 4 and 3 (each within the scatter of the next); then compound 1.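

In this assay, putting 4-isopropylphenyl in place of 3-chlorophenyl on the aromatic nitrogen gives a number 9.7 percentage points lower from compound 3 to compound 4 (within the scatter), so these two groups cannot be told apart here. A 4-alkylphenyl therefore does not in itself bring a low number: adding one methyl to the ethyl chain gives a number 14.3 percentage points higher from compound 2 to compound 4 (beyond the scatter), so a small change in that chain can matter at this position. No available measurement explains this shift. From the compounds shown here alone, whether a longer chain, such as butyl, would raise the number further remains open. So does the outcome of an amine or a carboxylic acid on this phenyl ring.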